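A bromo step from compound 1 to compound 4

A few compounds are considered here, and "the series" means these few. Any claim that something is new, unique, unknown or untested is made for them only; others in the source may bear on it.

Within the data shown here, in an ADME assay on a cell-free system (plasma, Mus musculus, strain CD-1) for protein binding, compound 1 `CCCS(=O)(=O)Nc1ccc(F)c(C(=O)Nc2cnc3[nH]ncc3c2)c1F` gives 87.1%, the highest unbound fraction among the three compounds measured so far. Compound 3 `CCCS(=O)(=O)Nc1ccc(F)c(C(=O)Nc2cnc3[nH]nc(OC)c3c2)c1F` gives 97.4%, and compound 2 `CCCS(=O)(=O)Nc1ccc(F)c(C(=O)Nc2cnc3[nH]cc(Br)c3c2)c1F`, which also carries a bromo but on a different core, gives 99.4%.

Compound 4 `CCCS(=O)(=O)Nc1ccc(F)c(C(=O)Nc2cnc3[nH]nc(Br)c3c2)c1F` departs from compound 1 by a single change, bromo in place of hydrogen on an aromatic carbon. Among the measured compounds shown here, the only measured single-place step that bears on it directly is a 5.0-fold lower unbound fraction from compound 1 to compound 3 (0.70 log units; beyond the scatter), seen for methoxy in place of hydrogen on an aromatic carbon. Compound 2 adds indirect support with its value of 99.4%, although its core differs, so it cannot give a clean step. Together these point to a lower unbound fraction, probably beyond the scatter and somewhat larger than the methoxy step. The expected change is an 8.6-fold lower unbound fraction from compound 1 to compound 4 (0.93 log units; beyond the scatter). For compound 4 the estimated value in this assay is 98.5%, with an expected range from 96.5% to 99.5%.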

Compound 4, plasma protein binding in the plasma assay: 98.4%
The estimate for compound 4 lay 1.1-fold (0.03 log units) (unbound fraction) below the measured number, and the stated range covers the measured number.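

In the plasma assay, the bromo on an aromatic carbon next to the ring nitrogen gives a clean single-place reading at this position: an 8.1-fold lower unbound fraction from compound 1 to compound 4 (0.91 log units; beyond the scatter). Set against methoxy on the same carbon, bromo gives a 1.6-fold lower unbound fraction from compound 3 to compound 4 (0.21 log units; within the scatter), so plasma protein binding does not tell these two groups apart here, and both stand well away from the hydrogen of compound 1. The same replacement of hydrogen by bromo also carries a large change in a physicochemical assay for solubility, read by HPLC, in phosphate buffer, with a stated time of 24 h, at pH 7.4; on this read-out higher numbers stand for higher solubility and lower numbers for lower solubility: the measured solubility of compound 1, 150 ug/mL, and of compound 4, 3 ug/mL, a 50-fold lower number (1.70 log units; beyond the scatter) In the physicochemical assay compound 1 gives 150 ug/mL, and compound 4 gives 3 ug/mL.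

The compounds shown leave open whether an amine or a carboxylic acid on this carbon would stay closer to compound 1 in plasma protein binding and solubility. They also leave open how a longer chain in this place would compare with bromo and methoxy.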